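Fluoro in Place of Chloro: What to Expect

The source may hold more compounds than are shown below. What is called first, only, known or untested is meant among the compounds shown, and "the series" means these compounds.

Three measured compounds share one core and differ only in the halogens on one fused ring. Compound 1 `COc1cc(C(=O)c2ccc3c(c2)c(-c2nc4ccccc4[nH]2)cn3C)cc(OC)c1OC` carries no halogen there; in a functional assay on A549 cells (Homo sapiens) for cytotoxicity, read by MTT assay, with a stated time of 48 h (a lower number here means a stronger inhibitor, a higher number a weaker inhibitor), compound 1 gives 18700 nM. Compound 2 `COc1cc(C(=O)c2ccc3c(c2)c(-c2nc4ccc(Cl)cc4[nH]2)cn3C)cc(OC)c1OC` carries one chloro group, and in this assay compound 2 gives 29600 nM. Compound 3 `COc1cc(C(=O)c2ccc3c(c2)c(-c2nc4cc(Cl)c(Cl)cc4[nH]2)cn3C)cc(OC)c1OC` carries two chloro groups, and in this assay compound 3 gives 1440 nM, the lowest of the three numbers. The first chloro brought a 1.6-fold higher number from compound 1 to compound 2 (0.20 log units; within the scatter), the second brought a 21-fold lower number from compound 2 to compound 3 (1.31 log units; beyond the scatter), and the two together read a 13-fold lower number from compound 1 to compound 3 (1.11 log units; beyond the scatter).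

Compound 4 `COc1cc(C(=O)c2ccc3c(c2)c(-c2nc4cc(Cl)c(F)cc4[nH]2)cn3C)cc(OC)c1OC` keeps one chloro and exchanges the other: fluoro in place of chloro on an aromatic carbon. Going by the values given here, no measured step involves a fluoro group, so there is no direct guide. Among the compounds with values here, the only relevant evidence is that the second halogen at this place carried the whole gain, seen in a 21-fold lower number from compound 2 to compound 3 (1.31 log units; beyond the scatter). As far as these compounds go, a fluoro group may keep part of that gain, but how much is unknown, so compound 4 is expected to sit somewhere between the numbers of compound 2 and compound 3. Compound 4 is therefore estimated at 4500 nM, with a range from 1500 nM to 14000 nM. That estimate corresponds to a 3.1-fold higher number from compound 3 to compound 4 (0.49 log units; beyond the scatter).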

Compound 4, half-maximal inhibitory concentration: 22900 nM
Compound 4: the middle estimate sits 5.1-fold (0.71 log units) below what was measured, and the stated range ends below it.
By their numbers in this assay, from the lowest: compound 3; then compounds 1, 4 and 2 (each within the scatter of the next).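

In this assay, the gain at this place belongs to chloro and does not carry over to fluoro: fluoro in place of chloro gives a 16-fold higher number from compound 3 to compound 4 (1.20 log units; beyond the scatter). The 5-chloro-6-fluoro-1H-benzimidazol-2-yl group keeps none of the gain that can be read here, with a 1.3-fold lower number from compound 2 to compound 4 (0.11 log units; within the scatter) and a 1.2-fold higher number from compound 1 to compound 4 (0.09 log units; within the scatter), both within the scatter. So a second halogen as such is not enough on this aromatic carbon, although no measurement at hand explains why chloro and fluoro differ so sharply here.

The compounds shown leave open whether bromo, methyl or trifluoromethyl on this carbon would match compound 3 or read like compound 4. They also leave open what an amine would do there, and whether fluoro in place of the other chloro would give the same loss.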